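The compounds below may be only part of what the source reports. "The series", "measured", "known", "first", "only" and "open" are said of these compounds alone.

In a physicochemical assay for solubility, in phosphate buffer, at pH 7.4 (on this read-out higher numbers stand for higher solubility and lower numbers for lower solubility), compound 1 `CC(C)n1nc(-c2ccnc3[nH]c(C4CCN(CC(=O)N(C)C)CC4)cc23)ccc1=O` gives 11000 nM and sits level with compound 2 `COc1cc(C(=O)N2CCCC2)ccc1-c1ccnc2[nH]c(C3CCOCC3)cc12` at 15000 nM on this scale, while compound 3 `CC(C)n1cc(-c2ccnc3[nH]c(C4CCN(CC(=O)N(C)C)CC4)cc23)cnc1=O` reaches 910000 nM on the same scale. Moving to compound 4 `CC(C)n1cc(-c2ccnc3[nH]c(C4CCN(CC(=O)N(C)C)CC4)cc23)ccc1=O` exchanges one ring-bearing group for another on an aromatic carbon of the shared core, and a group of 10 heavy atoms (8 carbon, 1 nitrogen, 1 oxygen; one six-membered aromatic ring with 1 hetero atom) in place of a group of 10 heavy atoms (7 carbon, 2 nitrogen, 1 oxygen; one six-membered aromatic ring with 2 hetero atoms), on an aromatic carbon is the whole change. Among the compounds with values here, compound 2 differs in more than one place, so the only measured step that bears on this is an 83-fold higher number from compound 1 to compound 3 (1.92 log units; beyond the scatter) at that same carbon. That swap kept the count of ring hetero atoms, whereas this one does not, so only part of it is expected to carry over. In this assay an upward move is expected, estimated as a 4.5-fold higher number from compound 1 to compound 4 (0.66 log units; beyond the scatter) in size. For compound 4 the estimated value is 50000 nM with an expected range from 10000 nM to 250000 nM in this measurement.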

Compound 4, solubility: 110000 nM
Beside the measured number, compound 4's estimate is 2.2-fold (0.34 log units) below it; measured number inside the range.
By their numbers in this assay, from the lowest: compounds 1 and 2 (each within the scatter of the next); then compound 4; then compound 3.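

In this assay, this aromatic carbon now shows a 10-fold higher number from compound 1 to compound 4 (1.00 log units; beyond the scatter) and an 8.3-fold lower number from compound 3 to compound 4 (0.92 log units; beyond the scatter), so the group with one ring hetero atom gives a number in the middle. The count of ring hetero atoms alone does not sort these three compounds: compound 1 and compound 3 share the same count yet give the two extreme numbers of the three. Nothing available here explains these differences. Still open, as far as these compounds go, is how a six-membered aromatic ring carrying an amine or a carboxylic acid would read at this carbon.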